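Hydroxy Addition on a Dichlorinated Lactone Scaffold

A few compounds are considered here, and "the series" means these few. Any claim that something is new, unique, unknown or untested is made for them only; others in the source may bear on it.

Compound 1 `O=C1OC[C@H](Cc2ccccc2)[C@H]1Cc1ccccc1`: 77000 nM
Compound 2 `O=C1OC[C@H](Cc2ccccc2)[C@H]1Cc1cccc(O)c1`: > 100000 nM
Compound 3 `O=C1OC[C@H](Cc2ccccc2)[C@H]1Cc1ccc(Cl)c(Cl)c1`: 19000 nM

In a functional assay on HL-60 cells (Homo sapiens) for cytotoxicity, read by WST assay, with a stated time of 48 h (a higher number here means that more compound is needed for the effect, a lower number that less compound is needed), compound 1 gives 77000 nM. Compound 2 reaches only a limit of the assay, > 100000 nM. Compound 3 gives 19000 nM, the lower of the two numbers measured, and its step from compound 1 is beyond the scatter. How the core of compound 3 differs from the core of compound 1 is not broken down here.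

The change from compound 1 to compound 2 is hydroxy in place of hydrogen on an aromatic carbon. It produced an at least 1.2-fold higher number from compound 1 to compound 2 (0.11 log units; that floor lies within the scatter), a floor set because compound 2 sits at the limit of > 100000 nM in this assay, at which 1 of the 3 values shown sits.

Compound 4 `O=C1OC[C@H](Cc2ccccc2O)[C@H]1Cc1ccc(Cl)c(Cl)c1` has not yet been measured. It differs from compound 3 by hydroxy in place of hydrogen on an aromatic carbon. This is the same kind of change as that from compound 1 to compound 2, but the place differs: there the hydroxy entered meta to a large group, here it enters ortho to a large group.

On this basis compound 4 is expected to give 32000 nM in this assay, a step of a 1.7-fold higher number from compound 3 to compound 4 (0.23 log units; within the scatter) that is estimated to resemble the earlier one, resting on the fact that compound 2 reached only > 100000 nM. The estimate for compound 4 is expected to lie between 12000 nM and 100000 nM.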

Compound 4, half-maximal effective concentration: 33000 nM
Compound 4: middle estimate off by 1.0-fold (0.01 log units), on the low side; the range from low to high includes it.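

On the core of compound 3, hydroxy in place of hydrogen on an aromatic carbon gave a 1.7-fold higher number from compound 3 to compound 4 (0.24 log units; within the scatter) in this assay, so on this core the change cannot be told apart from the usual variation between repeated measurements. Set beside the earlier step, the two readings compare as follows: the same change on two cores in this assay, an at least 1.2-fold higher number (0.11 log units; that floor lies within the scatter) from compound 1 to compound 2 and a 1.7-fold higher number (0.24 log units; within the scatter) from compound 3 to compound 4; the limit leaves it open whether they differ

From the compounds shown here alone, compound 2 stands at a limit of the assay, > 100000 nM, so the full size of the first step is unknown, and the two pairs show neither that the change carries over from one core to the other in equal measure nor that it does not, the more so as the hydroxy enters at a different place in each pair.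

The compounds shown leave open how the two cores would compare with the hydroxy at one and the same place on each of them. They also leave open how a methoxy group, an amine or a carboxylic acid would read in place of the hydroxy of compound 4 in this assay, and whether any such group would give a step beyond the scatter.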